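Fluoro to trifluoromethyl on the pendant phenyl

The source may report more compounds than this note shows. Statements on the series, on what has been measured and on what is new or still open speak of the compounds shown alone.

Compound 1 `c1ccc(C2=NN(c3ccc(-c4ccccc4)nn3)C(c3ccccc3)C2)cc1` is the parent of the pair. In a functional assay on A549 cells (Homo sapiens) for antiproliferative activity, read by MTT assay, with a stated time of 24 h (a lower number here means a stronger inhibitor, a higher number a weaker inhibitor), compound 1 returns only a limit, > 100000 nM. Among the measured compounds shown here, compound 2 `Fc1ccc(C2CC(c3ccccc3)=NN2c2ccc(-c3ccccc3)nn2)cc1`, fluoro in place of hydrogen on an aromatic carbon, gives 89200 nM in this assay, the only actual number in the set. The step of an at least 1.1-fold lower number from compound 1 to compound 2 (0.04 log units; that floor lies within the scatter) is read against a limit, (the limit of > 100000 nM in this assay, at which 1 of the 2 values shown sits). Compound 3 `FC(F)(F)c1ccc(C2CC(c3ccccc3)=NN2c2ccc(-c3ccccc3)nn2)cc1` differs from compound 2 by trifluoromethyl in place of fluoro on an aromatic carbon. No measured step covers this change, and the one step shown does not exceed the scatter, so nothing beyond the scatter is expected in this assay. The expected step of a 1.1-fold lower number from compound 2 to compound 3 (0.05 log units; within the scatter) is small. Compound 3 is estimated at 80000 nM, between 30000 nM and 200000 nM.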

Compound 3, half-maximal inhibitory concentration: 9160 nM
Beside the measured number, compound 3's estimate is 8.7-fold (0.94 log units) above it, and the stated range ends above it.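

In this assay this position, para to a large group, now shows a step beyond the scatter, which the fluoro step from the parent did not: trifluoromethyl in place of fluoro gives a 9.7-fold lower number from compound 2 to compound 3 (0.99 log units; beyond the scatter). Trifluoromethyl in place of hydrogen gives an at least 10-fold lower number from compound 1 to compound 3 (1.03 log units; beyond the scatter). Compound 1 stands only at a limit, so that step is a floor: the limit of > 100000 nM in this assay, at which 1 of the 3 values shown sits.

Open, going by these compounds, is whether a methoxy, a nitrile or an amine at this position would give a number like that of compound 3. Also open, on these data alone, is whether the step carries over to a core other than that of compound 1.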